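The source may hold more compounds than are shown below. What is called first, only, known or untested is meant among the compounds shown, and "the series" means these compounds.

Measured compounds:
compound 1 `CC(=O)OC(C)n1cnc2c(Cl)nc(N)nc21` — > 500000 nM
compound 2 `CC(=O)OCCOn1cnc2c(Cl)nc(N)nc21` — > 500000 nM

Of the compounds shown here, two have been tested in a functional assay on HeLa cells (Homo sapiens) for inhibition; on this read-out higher numbers stand for weaker inhibition and lower numbers for stronger inhibition. In this assay compound 1 gives > 500000 nM, which is a limit of the assay and not a number. Compound 2 likewise gives > 500000 nM in this assay, again a limit rather than a number. Going by the values given here, compound 1 therefore stands nowhere that can be ranked: both values sit at the limit of > 500000 nM in this assay, at which 2 of the 2 values shown sit, so no step between the two is known and nothing separates them.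

Compound 3 `CC(=O)OC(C)n1cnc2c(Cl)nc(I)nc21` remains to be measured. It differs from compound 1 by iodo in place of amino on an aromatic carbon. Among the compounds with values here, no measured pair with a comparable change exists here, so the size of this step cannot be drawn from the data. Given that compound 1 reaches only a limit, the step from compound 1 to compound 3 is expected to be a number no higher from compound 1 to compound 3 (the limit leaves the size open), with a real chance that compound 3 again returns only a limit. Compound 3 is accordingly estimated at 500000 nM in this assay, within a range from 100000 nM to 2000000 nM.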

Compound 3, half-maximal inhibitory concentration: 5130 nM
Beside the measured number, compound 3's estimate is 97-fold (1.99 log units) above it; the whole stated range lies above it.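

In this assay, going by these compounds alone, putting iodo in place of amino on this aromatic carbon, between two ring nitrogen atoms, gives an at least 97-fold lower number from compound 1 to compound 3 (1.98 log units; beyond the scatter), the first step in the set that can be read as a size. Compound 3 is also the only compound shown with a number rather than a limit, at 5130 nM, so this position can carry a change that moves the read-out towards stronger inhibition. Neither earlier compound could show this, as both carry amino at this carbon and stop at the same limit: the limit of > 500000 nM in this assay, at which 2 of the 3 values shown sit.

The compounds shown leave open whether the shift belongs to iodo itself or to the loss of amino, and a bromo group or a plain hydrogen at this carbon would bear on that. They also leave open whether iodo has a similar effect on the side chain of compound 2.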